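A few compounds are considered here, and "the series" means these few. Any claim that something is new, unique, unknown or untested is made for them only; others in the source may bear on it.

Measured in a physicochemical assay for lipophilicity, read by HPLC, using the shake flask method, measured as octanol-water partition, at pH 7.4 (a higher number here means a more lipophilic compound, a lower number a more polar compound), so far
- compound 1 `Cc1cc2ncccc2cc1Nc1ncc2c(n1)n(C1CCNCC1)c(=O)n2C` gives 0.5
- compound 2 `Cc1cc2ncccc2cc1Nc1ncc2c(n1)n([C@@H]1CCN(C)C1)c(=O)n2C` gives 1.2

Compound 2 holds the higher of the two values, and its gap to compound 1 lies beyond the scatter. The next compound to be read is compound 3 `Cc1cc2ncccc2cc1Nc1ncc2c(n1)n([C@H]1CCN(C3COC3)C1)c(=O)n2C`, which keeps the core of compound 2 and differs at one place. That change is 1-(oxetan-3-yl)pyrrolidin-3-yl in place of 1-methylpyrrolidin-3-yl on an aromatic nitrogen and amounts to 1-(oxetan-3-yl)pyrrolidin-3-yl in place of 1-methylpyrrolidin-3-yl on an aromatic nitrogen.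

Going by the values given here, only one measured step bears on this place, namely a number 0.70 log units higher from compound 1 to compound 2 (beyond the scatter) and it is modest but beyond the scatter. Among the compounds with values here, that step exchanges a different pair of groups, and no measured compound here carries an oxetan-3-yl group, so it offers a guide to scale and no direct precedent. A modest rise in this assay is expected on the scale of that single step, with the direction less secure than the size. The expected change is a number 0.60 log units higher from compound 2 to compound 3 (beyond the scatter) and it is held loosely. For compound 3 the estimate is 1.8 with an expected range from 1.3 to 2.3 as the working bounds.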

Compound 3, distribution coefficient: 1.5
Beside the measured number, compound 3's estimate is 0.30 log units above it; the range from low to high includes it.
By their numbers in this assay, from the lowest: compound 1; then compounds 2 and 3 (each within the scatter of the next).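

In this assay, the exchange of 1-methylpyrrolidin-3-yl for 1-(oxetan-3-yl)pyrrolidin-3-yl on the aromatic nitrogen gives a number 0.30 log units higher from compound 2 to compound 3 (within the scatter), so this read-out does not separate compound 2 from compound 3 even though the entering group brings a four-membered non-aromatic ring and a further hydrogen-bond acceptor. The position therefore accepts this larger group with no change beyond the scatter, while the replacement of piperidin-4-yl gives a number 1.00 log units higher from compound 1 to compound 3 (beyond the scatter), which stands with the earlier a number 0.70 log units higher from compound 1 to compound 2 (beyond the scatter) in placing both pyrrolidine-bearing compounds clear of compound 1. Nothing measured here explains these numbers.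

The comparison with compound 1 changes the ring and the group on its nitrogen together, so the shares of the two remain unresolved; an unsubstituted pyrrolidin-3-yl or a 1-(oxetan-3-yl)piperidin-4-yl group would divide that step into its parts. Also open, from the compounds shown here alone, is how far this tolerance extends to other groups on the pyrrolidine nitrogen, such as an acetyl group, a longer alkyl chain or a chain ending in a carboxylic acid.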